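Chloro for fluoro at the limit of the assay

The source may report more compounds than this note shows. Statements on the series, on what has been measured and on what is new or still open speak of the compounds shown alone.

In a functional assay on MCF7 cells (Homo sapiens) for cytotoxicity, read by MTT assay, with a stated time of 24 h (on this read-out lower numbers stand for stronger inhibition and higher numbers for weaker inhibition), compound 1 (`Cc1ccc(/C=C2\CN(C(=S)SCc3cn(Cc4ccc(F)cc4)nn3)C/C(=C\c3ccc(C)cc3)C2=O)cc1`) gives 81600 nM as its value. Compound 2 (`Cc1ccc(/C=C2\CN(C(=S)SCc3cn(Cc4ccccc4F)nn3)C/C(=C\c3ccc(C)cc3)C2=O)cc1`) gives > 100000 nM which is a limit and not a number. Compound 3 (`Cc1ccc(/C=C2\CN(C(=S)SCc3cn(Cc4ccccc4Cl)nn3)C/C(=C\c3ccc(C)cc3)C2=O)cc1`) differs from compound 2 by chloro in place of fluoro on an aromatic carbon and so has chloro in place of fluoro on an aromatic carbon. Among the measured compounds shown here, the one measured step, an at least 1.2-fold higher number from compound 1 to compound 2 (0.08 log units; that floor lies within the scatter) in size, exchanged no fluoro for chloro and offers only a loose guide. An estimated a number no higher from compound 2 to compound 3 (the limit leaves the size open) is expected, meaning no change beyond the scatter. Compound 3 is estimated at 100000 nM with an expected range of 50000 nM to 200000 nM in this test.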

Compound 3, half-maximal inhibitory concentration: > 100000 nM
Compound 3: only a limit was reported; the forecaster's own chance of this, stated with the estimate: 60%; the middle value lies on the limit itself.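

Compound 3, like compound 2, gives a limit and not a number, so the exchange of fluoro for chloro on this aromatic carbon cannot be read, because both values rest on the same limit: the limit of > 100000 nM in this assay, at which 2 of the 3 values shown sit. Among the compounds shown here, the one readable comparison is an at least 1.2-fold higher number from compound 1 to compound 3 (0.08 log units; that floor lies within the scatter), which is a floor and not a measured size. Chloro here therefore brings no value back into the range where numbers can be compared.

Going by these compounds, it remains open how a methoxy group or an amine on this aromatic carbon would read, and whether any group placed here would give a true number.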